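The source may report more compounds than this note shows. Statements on the series, on what has been measured and on what is new or still open speak of the compounds shown alone.

Measured so far:
Compound 1 `CCCCCCCCC(=O)NCc1cc(I)c(O)c(OC)c1` gives 126 nM in an assay on HEK293 cells for inhibition of transient receptor potential cation channel subfamily V member 1 (Homo sapiens); on this read-out higher numbers stand for weaker inhibition and lower numbers for stronger inhibition.
Compound 2 `CCCCCCCCC(=O)NCc1cc(OC)c(O)cc1Br` gives 16.1 nM in this assay.
Compound 3 `CCCCCCCCC(=O)NCc1cc(Cl)c(O)c(OC)c1` gives 631 nM in this assay.

Compound 3 stands at the highest, that is weakest, number of the three; compound 1 is its nearest neighbour and compound 2 lies furthest below it. Within the data shown here, the one step that touches the same position is the change from iodo to chloro, which gave a 5.0-fold higher number from compound 1 to compound 3 (0.70 log units; beyond the scatter). Compound 4 `CCCCCCCCC(=O)NCc1cc(CC)c(O)c(OC)c1` differs from compound 3 in just that place: ethyl in place of chloro on an aromatic carbon. Among the measured compounds shown here, no measured pair shows what an ethyl group does here, so the only guide is that this position has already shifted the number well beyond the scatter once. The step from compound 3 to compound 4 in this assay is therefore expected to be modest and downward, a 2.5-fold lower number from compound 3 to compound 4 (0.40 log units; beyond the scatter), though with wide uncertainty. Compound 4 is estimated at 250 nM in this assay, within a range of 60 nM to 1000 nM.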

Compound 4, half-maximal inhibitory concentration: 355 nM
Beside the measured number, compound 4's estimate is 1.4-fold (0.15 log units) below it; measured number inside the range.
By their numbers in this assay, from the lowest: compound 2; then compound 1; then compounds 4 and 3 (each within the scatter of the next).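

In this assay, ethyl in place of chloro on this aromatic carbon, ortho to a hydroxy group, gives a 1.8-fold lower number from compound 3 to compound 4 (0.25 log units; within the scatter) and so stays within the scatter; at this place the two groups cannot be told apart, although ethyl brings in one more heavy atom. Iodo, by contrast, now stands apart from both groups: ethyl in place of iodo gives a 2.8-fold higher number from compound 1 to compound 4 (0.45 log units; beyond the scatter) and lies beyond the scatter, as does the earlier step of a 5.0-fold higher number from compound 1 to compound 3 (0.70 log units; beyond the scatter) for chloro in place of iodo. The position therefore responds to some changes and not to others, and the step from chloro to ethyl is not one that can be read as a shift.

As far as these compounds go, whether a propyl chain, a nitrile or an amine at this place would side with iodo or with chloro and ethyl remains open. No measurement given here bears on why iodo stands apart.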